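A few compounds are considered here, and "the series" means these few. Any claim that something is new, unique, unknown or untested is made for them only; others in the source may bear on it.

In an ADME assay on microsomes from liver (Rattus norvegicus) for metabolic stability, read by LC-MS, with a stated time of 30 min, tested at 0.5 uM (a lower number here means that less of the compound is left, a higher number that more of the compound is left), compound 3 (`Oc1cccc(-c2nc(-c3csc(N=C4NCCCN4)n3)cs2)c1`) gives 35% and stands within the scatter of compound 1 (`c1ccc(-c2nc(-c3csc(N=C4NCCCN4)n3)cs2)cc1`) at 31% while compound 2 (`c1ccc(-n2ccc(-c3csc(N=C4NCCCN4)n3)n2)cc1`) gives only 1.6% on the same read-out. Compound 4 (`c1cc(-c2nc(-c3csc(N=C4NCCCN4)n3)cs2)ccn1`) has pyridin-4-yl in place of 3-hydroxyphenyl on an aromatic carbon. For the measured compounds named here, the one measured step that bears on this is a number 4 percentage points higher from compound 1 to compound 3 (within the scatter) for hydroxy in place of hydrogen on an aromatic carbon, so the loss of the hydroxy alone is not expected to count for much. Going by the values given here, no measured step covers pyridin-4-yl, which leaves the estimate uncertain. The expected step is a number 7 percentage points lower from compound 3 to compound 4 (within the scatter) and no change beyond the scatter is expected. In this assay compound 4 is estimated at 28% and expected to lie from 10% to 50% in repeat measurements.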

Compound 4, percent of the compound remaining: 9%
Compound 4: middle estimate off by 19 percentage points, on the high side, outside the stated range (below it).
By their numbers in this assay, from the lowest: compounds 2 and 4 (each within the scatter of the next); then compounds 1 and 3 (each within the scatter of the next).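

For the compounds shown here, this position tolerates less than the earlier compounds suggested: in this assay there is a number 22 percentage points lower from compound 1 to compound 4 (beyond the scatter) on going from phenyl to pyridin-4-yl and a number 26 percentage points lower from compound 3 to compound 4 (beyond the scatter) on going from 3-hydroxyphenyl to pyridin-4-yl. Going by these compounds alone, the hydroxy step had stayed within the scatter, so this is the first change on this aryl ring to go beyond it. Nothing available explains the drop. On these data alone, it remains open whether the fall belongs to pyridin-4-yl alone or would also follow with pyridin-3-yl or pyridin-2-yl, and how a methoxy group or an amine on the phenyl ring would read.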